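Acetoxy to hydroxy on a shared core: working notes

The compounds below may be only part of what the source reports. "The series", "measured", "known", "first", "only" and "open" are said of these compounds alone.

In a functional assay on MCF7 cells (Homo sapiens) for antiproliferative activity (on this read-out higher numbers stand for weaker inhibition and lower numbers for stronger inhibition), compound 1 `COc1ccc(-c2cn(-c3cc4ccc(O)c(C)c4oc3=O)nn2)cc1` gives > 100000 nM, which is a limit of the assay and not a number. Compound 2 `COc1ccc(-c2cn(-c3cc4ccc(OC(C)=O)c(C)c4oc3=O)nn2)cc1` gives > 100000 nM, again a limit. Compound 3 `CC(=O)Oc1ccc2cc(-n3cc(-c4c[nH]c5ccccc45)nn3)c(=O)oc2c1C` gives 7450 nM. The change from compound 2 to compound 3 is 1H-indol-3-yl in place of 4-methoxyphenyl on an aromatic carbon; it makes an at least 13-fold lower number from compound 2 to compound 3 (1.12 log units; beyond the scatter). The change from compound 2 to compound 1 is hydrogen in place of acetyl on an oxygen on an aromatic ring, and its step reads a step that the two limits leave unreadable from compound 2 to compound 1 because of the limit of > 100000 nM in this assay, at which 2 of the 3 values shown sit. Compound 4 `Cc1c(O)ccc2cc(-n3cc(-c4c[nH]c5ccccc45)nn3)c(=O)oc12` is not yet measured; it differs from compound 3 by hydrogen in place of acetyl on an oxygen on an aromatic ring, the same change at the same place. The earlier step gives no readable size, so the expectation rests only on compound 3 with 7450 nM and is wide. The step is expected to be a 1.3-fold higher number from compound 3 to compound 4 (0.13 log units; within the scatter). Compound 4 is estimated at 10000 nM, between 2500 nM and 40000 nM.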

Compound 4, half-maximal inhibitory concentration: 8170 nM
For compound 4 the middle estimate is 1.2-fold (0.09 log units) above the measured one, and the stated range covers the measured number.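

In this assay, acetoxy to hydroxy gives a 1.1-fold higher number from compound 3 to compound 4 (0.04 log units; within the scatter), while the same change on the 4-methoxyphenyl compounds cannot be read, so its carry-over between cores remains untested. 1H-indol-3-yl in place of 4-methoxyphenyl gives an at least 12-fold lower number from compound 1 to compound 4 (1.08 log units; beyond the scatter) with the hydroxy group present, matching the direction seen with the acetoxy group: the same change on two cores in this assay, an at least 13-fold lower number (1.12 log units; beyond the scatter) from compound 2 to compound 3 and an at least 12-fold lower number (1.08 log units; beyond the scatter) from compound 1 to compound 4; the limit leaves it open whether they differ The exact size of this step on either core is therefore not shown, and only a lower bound is available: the limit of > 100000 nM in this assay, at which 2 of the 4 values shown sit.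

As far as these compounds go, the effect of a methoxy group or a longer acyl chain on that oxygen remains open. So does the effect of an amine or a carboxylic acid in place of 1H-indol-3-yl on the aromatic carbon.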